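The source may report more compounds than this note shows. Statements on the series, on what has been measured and on what is new or still open speak of the compounds shown alone.

Measured in a functional assay on MCF7 cells (Homo sapiens) for cytotoxicity, read by MTT assay, with a stated time of 96 h; on this read-out higher numbers stand for weaker inhibition and lower numbers for stronger inhibition:
compound 1 `COc1cc(C(=O)c2cn(-c3ccccc3C)cc2-c2ccccc2)cc(OC)c1OC`: 2200 nM
compound 2 `COc1cccc(-n2cc(C(=O)c3cc(OC)c(OC)c(OC)c3)c(-c3ccccc3)c2)c1`: 500 nM

Of these two, compound 2 holds the lower number, 500 nM, and so the stronger inhibition. The next compound, compound 3 `COc1cc(C(=O)c2cn(-c3ccc(Br)cc3)cc2-c2ccccc2)cc(OC)c1OC`, keeps the shared core and changes one group: 4-bromophenyl in place of 3-methoxyphenyl on an aromatic nitrogen. In words, 4-bromophenyl stands in place of 3-methoxyphenyl on an aromatic nitrogen. Among the compounds with values here, only one measured step bears on this, and it lies on that same nitrogen: a 4.4-fold lower number from compound 1 to compound 2 (0.64 log units; beyond the scatter). Within the data shown here, that modest step is the sole guide. Among the measured compounds shown here, with the 3-methoxyphenyl group of compound 2 leaving, a somewhat smaller step toward a higher number is expected in this assay, although no measured compound carries bromine. The expected move is a 2.4-fold higher number from compound 2 to compound 3 (0.38 log units; beyond the scatter). The estimate for compound 3 is 1200 nM, with an expected range from 300 nM to 4500 nM.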

Compound 3, half-maximal inhibitory concentration: 20 nM
Compound 3: the middle estimate sits 60-fold (1.78 log units) above what was measured; the measured number lies below the stated range.
By their numbers in this assay, from the lowest: compound 3; then compound 2; then compound 1.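

In this assay, the group on the aromatic nitrogen proves able to move the number much further than the earlier pair showed: a 25-fold lower number from compound 2 to compound 3 (1.40 log units; beyond the scatter), and a 110-fold lower number from compound 1 to compound 3 (2.04 log units; beyond the scatter), against only a 4.4-fold lower number from compound 1 to compound 2 (0.64 log units; beyond the scatter) before. Compound 3, with its 4-bromophenyl group, thus stands apart from both compounds carrying other substituted phenyl groups on that nitrogen, and its steps to each lie beyond the scatter. The entering group differs from 3-methoxyphenyl by swapping an oxygen-bearing group for bromine and by having no hydrogen-bond acceptor, but nothing at hand explains why this change has so large an effect.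

The compounds shown leave open whether the gain belongs to bromine itself or to where it sits, as 3-bromophenyl would help to show. Going by these compounds, it also remains open whether 4-chlorophenyl, 4-methylphenyl or 4-methoxyphenyl on that nitrogen would give a similar number.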